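Adding a methyl to the amide of the 3-methylbenzyl analogue

The source may hold more compounds than are shown below. What is called first, only, known or untested is meant among the compounds shown, and "the series" means these compounds.

Compound 1 `CC(C)c1c(C(=O)NCc2cccc(F)c2F)nn(-c2ccc(F)cc2)c1OC[C@@H](O)C[C@@H](O)CC(=O)O` gives 2 nM in an assay on microsomes from liver for inhibition of 3-hydroxy-3-methylglutaryl-coenzyme A reductase (Rattus norvegicus) (a higher number here means a weaker inhibitor, a lower number a stronger inhibitor), the lowest of the three numbers. Compound 2 `Cc1cccc(CNC(=O)c2nn(-c3ccc(F)cc3)c(OC[C@@H](O)C[C@@H](O)CC(=O)O)c2C(C)C)c1` gives 4.9 nM, and compound 3 `CC(C)c1c(C(=O)N(C)Cc2cccc(F)c2)nn(-c2ccc(F)cc2)c1OC[C@@H](O)C[C@@H](O)CC(=O)O` gives 14 nM in this assay. Compound 4 `Cc1cccc(CN(C)C(=O)c2nn(-c3ccc(F)cc3)c(OC[C@@H](O)C[C@@H](O)CC(=O)O)c2C(C)C)c1` differs from compound 1 by methyl(3-methylbenzyl)amino in place of (2,3-difluorobenzyl)amino on a carbonyl carbon. This change combines two steps already seen: a 2.5-fold higher number from compound 1 to compound 2 (0.39 log units; beyond the scatter) for the aryl swap, and a 7.0-fold higher number from compound 1 to compound 3 (0.85 log units; beyond the scatter) together with a 2.9-fold higher number from compound 2 to compound 3 (0.46 log units; beyond the scatter) for methylation of the amide nitrogen alongside a further aryl change. Both steps raised the number, so a loss beyond the scatter is expected for compound 4, about the size of a 7.5-fold higher number from compound 1 to compound 4 (0.88 log units; beyond the scatter). Compound 4 is therefore estimated at 15 nM in this assay, with a range of 6 nM to 40 nM.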

Compound 4, half-maximal inhibitory concentration: 37 nM
The estimate for compound 4 lay 2.5-fold (0.39 log units) below the measured number; the measured number falls inside the stated range.
By their numbers in this assay, from the lowest: compound 1; then compound 2; then compound 3; then compound 4.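

Methyl in place of hydrogen on the amide-type nitrogen, now seen as a single change, gives a 7.6-fold higher number from compound 2 to compound 4 (0.88 log units; beyond the scatter) in this assay, which accounts for most of a 19-fold higher number from compound 1 to compound 4 (1.27 log units; beyond the scatter). With that nitrogen methylated, methyl in place of fluoro on an aromatic carbon still gives a 2.6-fold higher number from compound 3 to compound 4 (0.42 log units; beyond the scatter), so the aromatic substituent continues to matter in the methylated amide. The data offer no measured reason for these losses.

Going by these compounds, it remains open whether ethyl on the amide nitrogen would cost as much as methyl. On these data alone, whether chloro on the aromatic ring would behave like fluoro or like methyl also remains open.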